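This account rests on a few compounds, and the source may have more. Where it says the series, first, only, none or still open, it means among the compounds named here.

Compound 1, `COc1cc(-c2nccn2C)cc(OC)c1OC`: in a functional assay on HT-29 cells (Homo sapiens) for antiproliferative activity, read by MTT assay, with a stated time of 72 h (a lower number here means a stronger inhibitor, a higher number a weaker inhibitor), compound 1 gives > 100000 nM, which is a limit of the assay and not a number.
Compound 2, `COc1cc(-c2nccn2Cc2ccccc2)cc(OC)c1OC`: compound 2 gives > 100000 nM, again a limit of the assay rather than a number.
Compound 3, `COc1cc(-c2nccn2-c2ccc(C)cc2)cc(OC)c1OC`: compound 3 gives 1600 nM.

Compound 1 therefore stands at the edge of what this assay can report, and so does one other compound, since two of the three values sit at the limit of > 100000 nM in this assay, at which 2 of the 3 values shown sit. The unmeasured compound 4, `COc1cc(-c2nccn2-c2cccc(C)c2)cc(OC)c1OC`, differs from compound 1 in a single place: 3-methylphenyl in place of methyl on an aromatic nitrogen.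

The measured step that speaks most directly to this change is an at least 62-fold lower number from compound 1 to compound 3 (1.79 log units; beyond the scatter), where a methyl-bearing phenyl ring also took the place of methyl on the same nitrogen; the parallel step an at least 62-fold lower number from compound 2 to compound 3 (1.79 log units; beyond the scatter) points the same way. By contrast a step that the two limits leave unreadable from compound 1 to compound 2 teaches nothing about size. A large lowering of the number is therefore expected for compound 4, of about an at least 40-fold lower number from compound 1 to compound 4 (1.60 log units; beyond the scatter). Compound 4 is estimated at 2500 nM, with a likely range from 600 nM to 12000 nM.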

Compound 4, half-maximal inhibitory concentration: 14600 nM
Compound 4: the middle estimate sits 5.8-fold (0.77 log units) below what was measured, outside the stated range (above it).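

Moving the methyl around the phenyl ring matters: in this assay there is a 9.1-fold higher number from compound 3 to compound 4 (0.96 log units; beyond the scatter), so 3-methylphenyl and 4-methylphenyl are not interchangeable on this aromatic nitrogen, a difference that no earlier comparison could show. The 3-methylphenyl group still keeps an advantage over both methyl and benzyl, with an at least 6.8-fold lower number from compound 1 to compound 4 (0.83 log units; beyond the scatter) and an at least 6.8-fold lower number from compound 2 to compound 4 (0.83 log units; beyond the scatter). Both of these steps start from a limit, so they give a floor on the size and not the size itself: the limit of > 100000 nM in this assay, at which 2 of the 4 values shown sit.

The compounds shown leave open whether the phenyl ring needs its methyl at all, and a plain phenyl group on the same nitrogen would speak to that. They also leave open whether the lower number of the 4-methylphenyl group depends on methyl itself or would hold with 4-methoxyphenyl or 4-aminophenyl.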